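The compounds below may be only part of what the source reports. "The series", "measured", "known", "first", "only" and "open" are said of these compounds alone.

Measured so far in a functional assay on HEK293 cells for agonist activity at Glucose-dependent insulinotropic receptor (Homo sapiens), read by cAMP accumulation, with a stated time of 60 min; a lower number here means that less compound is needed, a higher number that more compound is needed for the effect:
compound 1 `COc1cc2nc(Nc3ccc(S(C)(=O)=O)cc3)nc(N3CCC4CCC(C3)N4Cc3ccccc3)c2cc1OC` gives > 10000 nM, a limit of the assay.
compound 2 `COc1cc2nc(Nc3ccc(S(C)(=O)=O)cc3)nc(N3CCC4CCC(C3)N4C(=O)OC(C)(C)C)c2cc1OC` gives > 10000 nM, also a limit.
compound 3 `COc1cc2nc(N3CCC4CCC(C3)N4Cc3ccccc3)nc(Nc3ccc(S(C)(=O)=O)cc3)c2cc1OC` gives > 10000 nM, again a limit.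

Compound 3 thus stands at the limit in this assay, as do the other two values shown (the limit of > 10000 nM in this assay, at which 3 of the 3 values shown sit). Going by the values given here, the one measured single-point step, a step that the two limits leave unreadable from compound 1 to compound 2, is unreadable between two limits, so no step size is available from the series.

Compound 4 `COc1cc2nc(N3CCC4CCC(C3)N4Cc3ccccc3)nc(Nc3ccc(S(C)(=O)=O)cc3F)c2cc1OC` differs from compound 3 by fluoro in place of hydrogen on an aromatic carbon. Among the compounds with values here, no measured step bears on this change. With nothing in the series pointing away from the limit, compound 4 is expected to remain there, the expected step that the limit leaves unreadable from compound 3 to compound 4 being none beyond the scatter. The estimate for compound 4 in this assay is 15000 nM, within 3000 nM to 60000 nM, most likely reported again as a limit.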

Compound 4, half-maximal effective concentration: > 10000 nM
Compound 4 ended at the assay's limit (the forecaster's own chance of this, stated with the estimate: 80%); the middle value lies beyond the limit too.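

Compound 3 and compound 4 both sit at the assay's limit, so the step between them, fluoro in place of hydrogen, cannot be read: the limit of > 10000 nM in this assay, at which 4 of the 4 values shown sit.

The compounds shown leave open what change to the shared core would give a value inside the assay's range.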